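Methoxy in Place of Methyl on the Sulfonamide Ring

The source may hold more compounds than are shown below. What is called first, only, known or untested is meant among the compounds shown, and "the series" means these compounds.

The measured compounds, all tested in an assay on cells for inhibition of HSP60/HSP10 (Homo sapiens), with a stated time of 60 min; on this read-out higher numbers stand for weaker inhibition and lower numbers for stronger inhibition:
Compound 1 `Cc1ccccc1S(=O)(=O)Nc1ccc(-c2nc3ccccc3o2)cc1` gives 85000 nM.
Compound 2 `O=S(=O)(Nc1ccc2oc(-c3ccccc3)nc2c1)c1ccc(Cl)c(C(F)(F)F)c1` gives only a limit of the assay, > 100000 nM.
Compound 3 `O=S(=O)(Nc1ccc2oc(-c3ccccc3)nc2c1)c1ccc(O)cc1` gives 88000 nM.

Among the two compounds that return a number in this assay, compound 1 has the lowest value, but compound 3 sits so close to it that the two cannot be told apart. The remaining value is a limit: compound 2 reaches (the limit of > 100000 nM in this assay, at which 1 of the 3 values shown sits), so no number is known for it. Compound 2 and compound 3 also carry their sulfonamide on a different part of the shared core than compound 1 does, so they show only that weak inhibition is common here.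

The unmeasured compound 4 `COc1ccccc1S(=O)(=O)Nc1ccc(-c2nc3ccccc3o2)cc1` is compound 1 with methoxy in place of methyl on an aromatic carbon.

Going by the values given here, no measured pair differs in a single place, so the size of this change is not known from these data. The step from compound 1 to compound 4 is expected to be small, with no clear direction, and likely within the scatter: a 1.1-fold higher number from compound 1 to compound 4 (0.02 log units; within the scatter). Compound 4 is estimated at 90000 nM in this assay, between 40000 nM and 200000 nM, with a fair chance that only a limit is reported.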

Compound 4, half-maximal inhibitory concentration: > 100000 nM
Compound 4 gave a limit, no number; the forecaster's own chance of this, stated with the estimate: 40%; middle value at least 1.1-fold (0.04 log units) away from the limit.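

In this assay compound 4 returns only a limit of the assay, > 100000 nM, and not a number. This is the first change in a single place among these compounds, methoxy in place of methyl on an aromatic carbon ortho to a large group, and it gives an at least 1.1-fold higher number from compound 1 to compound 4 (0.07 log units; that floor lies within the scatter): the swap brings no visible gain in inhibition, while the true size of the step stays unknown, and the floor printed for it lies within the scatter. Values at the end of the measurable range are now as common as numbers: the limit of > 100000 nM in this assay, at which 2 of the 4 values shown sit.

The compounds shown leave open whether the step from methyl to methoxy is small or large. They also leave open how an amine, a carboxylic acid or a longer chain at this position would compare with compound 1.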